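The compounds below may be only part of what the source reports. "The series", "measured", "known", "first", "only" and "open" are said of these compounds alone.

Measured so far in an ADME assay on the whole organism (serum, Rattus norvegicus) for protein binding; on this read-out higher numbers stand for a larger free fraction and lower numbers for a smaller free fraction:
- compound 1 `O=C(C1=C(O)C(=O)N(c2ccc(-c3ccon3)cc2)C1C1CCCCC1)c1ccc(CO)cc1`: 0.004
- compound 2 `CCC(CC)C1C(C(=O)c2ccc(OC)cc2)=C(O)C(=O)N1c1ccc(-c2ccon2)cc1`: 0.0002
- compound 3 `COc1ccc(C(=O)C2=C(O)C(=O)N(c3ccc(-c4ccon4)cc3)C2c2ccccc2OC)cc1`: 0.0049

Compound 3 stands at the upper end of the three numbers in this assay. For the measured compounds named here, its gap to compound 1 is within the scatter, so the two cannot be ordered; its gap to compound 2 is beyond the scatter, and that gap is the one measured step, a 25-fold higher number from compound 2 to compound 3 (1.39 log units; beyond the scatter), a change at the saturated ring carbon.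

Compound 4 `COc1ccccc1C1C(C(=O)C(C)(C)C)=C(O)C(=O)N1c1ccc(-c2ccon2)cc1` differs from compound 3 at a different site: tert-butyl in place of 4-methoxyphenyl on a carbonyl carbon. Going by the values given here, no measured pair changes the group on the carbonyl carbon, so the only measured step does not bear on this change, and the expectation rests on compound 3 alone. Among the compounds with values here, without a relevant precedent, the estimate stays close to compound 3, with wide bounds allowing a modest move in either direction and no step claimed beyond the scatter. For compound 4 the expected unbound fraction in this assay is 0.007 (range 0.0025 to 0.02), which would be an expected step of a 1.4-fold higher number from compound 3 to compound 4 (0.15 log units; within the scatter) from compound 3.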

Compound 4, unbound fraction: 0.002
For compound 4 the middle estimate is 3.5-fold (0.54 log units) above the measured one, and the stated range ends above it.
By their numbers in this assay, from the lowest: compound 2; then compounds 4, 1 and 3 (each within the scatter of the next, the first and the last beyond it).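

In this assay, the group on the carbonyl carbon also moves the free fraction: (tert-butyl)carbonyl in place of (4-methoxyphenyl)carbonyl gives a 2.5-fold lower number from compound 3 to compound 4 (0.39 log units; beyond the scatter), a modest step at a site where no change had been measured before. The leaving 4-methoxyphenyl carries a six-membered aromatic ring and a hydrogen-bond acceptor, while tert-butyl carries neither, so this single step cannot separate the ring from the acceptor. No measurement available here accounts for the lower number.

Still open, as far as these compounds go, is how a carboxylic acid or an amine on this carbonyl carbon would read out. From the compounds shown here alone, it is also open whether the step holds with pentan-3-yl or cyclohexyl, rather than 2-methoxyphenyl, on the saturated ring carbon.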